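A few compounds are considered here, and "the series" means these few. Any claim that something is new, unique, unknown or untested is made for them only; others in the source may bear on it.

Measured compounds in an ADME assay on BHK-21 cells (Mesocricetus auratus) for cytotoxicity, read by MTT assay, with a stated time of 72 h; a lower number here means that less compound is tolerated, a higher number that more compound is tolerated:
compound 1 `Cc1ccc(-c2nn(-c3ccccc3)cc2CNc2ccc(Br)cc2)cc1`: > 100000 nM, a limit of the assay rather than a number.
compound 2 `FC(F)(F)c1ccc(-c2nn(-c3ccccc3)cc2CNc2ccc(Br)cc2)cc1`: 28000 nM.
compound 3 `Clc1ccc(NCc2cn(-c3ccccc3)nc2-c2ccc(Br)cc2)cc1`: > 100000 nM; > 100000 nM (2 entries), both entries limits of the assay rather than numbers.

Compound 1 stands at the limit of > 100000 nM in this assay, at which 1 of the 3 values shown sits, so only a limit and no single number is known for it. Among the measured compounds shown here, the one step measured within the set, an at least 3.5-fold lower number from compound 1 to compound 2 (0.55 log units; beyond the scatter), concerns trifluoromethyl in place of methyl on an aromatic carbon, a different group than the one considered here, and it is the only change that moves the read-out beyond the scatter.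

Compound 4 `Cc1ccc(NCc2cn(-c3ccccc3)nc2-c2ccc(C)cc2)cc1` differs from compound 1 by methyl in place of bromo on an aromatic carbon. For the measured compounds named here, no measured step covers this change. Compound 3 also gives only a limit in this assay. With the two limit compounds as the nearest points of reference, no step beyond the scatter is expected for compound 4, which is expected to remain at the limit, a step that the limit leaves unreadable from compound 1 to compound 4. Compound 4 is estimated at 150000 nM, with a range of 50000 nM to 500000 nM, most likely reported only as a limit.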

Compound 4, half-maximal cytotoxic concentration: > 100000 nM
Compound 4: a limit, no number; the forecaster's own chance of this, stated with the estimate: 80%; the middle value is on the limit's open side.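

Compound 1 and compound 4 both give only a limit in this assay, so no step can be read for methyl in place of bromo: the limit of > 100000 nM in this assay, at which 2 of the 4 values shown sit.

The compounds shown leave open how far this change moves the read-out, if it moves it at all.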